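Toward compound 4: a larger group on the ring carbon

This account rests on a few compounds, and the source may have more. Where it says the series, first, only, none or still open, it means among the compounds named here.

Compound 3 `COc1ccc2[nH]c(C(=O)N3CC(=O)N(Cc4ccccc4)[C@@H](N4CCc5ccccc54)C3)cc2c1` is the reference point. In an ADME assay on Vero cells (Chlorocebus sabaeus) for cytotoxicity, with a stated time of 7 days (on this read-out higher numbers stand for lower toxicity in this test and lower numbers for higher toxicity in this test), compound 3 gives > 100000 nM, and that value is a limit of the assay rather than a number. Of the two other compounds measured in this assay, compound 1 `COc1ccc2[nH]c(C(=O)N3CC(=O)N(Cc4ccccc4)[C@@H](CN4CCCCC4)C3)cc2c1` gives 76900 nM. Compound 2 `COc1ccc2[nH]c(C(=O)N3CC(=O)N(Cc4ccccc4)[C@@H](COCc4ccccc4)C3)cc2c1` gives > 30000 nM, which is again a limit. Compound 3 thus stands at the upper bound of what was measured, with one further value also known only as a limit.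

Compound 4 `COc1ccc2[nH]c(C(=O)N3CC(=O)N(Cc4ccccc4)[C@@H](CN4C(=O)c5ccccc5C4=O)C3)cc2c1` differs from compound 3 in one place: a group of 12 heavy atoms (9 carbon, 1 nitrogen, 2 oxygen; one five-membered non-aromatic ring with 1 hetero atom, one six-membered aromatic ring of carbon only) in place of a group of 9 heavy atoms (8 carbon, 1 nitrogen; one five-membered non-aromatic ring with 1 hetero atom, one six-membered aromatic ring of carbon only), on a saturated ring carbon. The measured steps offer little firm ground. The step of an at least 1.3-fold higher number from compound 1 to compound 3 (0.11 log units; that floor lies within the scatter) has a readable floor that lies within the scatter. The step that the limit leaves unreadable from compound 1 to compound 2 cannot be sized because of the limit of > 30000 nM in this assay, at which 1 of the 3 values shown sits, and the step that the two limits leave unreadable from compound 2 to compound 3 cannot be sized because of the limit of > 100000 nM in this assay, at which 1 of the 3 values shown sits, and (the limit of > 30000 nM in this assay, at which 1 of the 3 values shown sits). All three compounds sit in the same low-toxicity region, so no step beyond the scatter is expected in this assay for the change to compound 4. Compound 4 is therefore expected to give about 90000 nM, between 35000 nM and 250000 nM, a step of an at least 1.1-fold lower number from compound 3 to compound 4 (0.04 log units; that floor lies within the scatter) that is expected to stay within the scatter.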

Compound 4, half-maximal cytotoxic concentration: 41000 nM
Compound 4: the middle estimate sits 2.2-fold (0.34 log units) above what was measured, and the stated range covers the measured number.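

In this assay, the change at this saturated ring carbon gives the only step shown that is readable beyond the scatter, an at least 2.4-fold lower number from compound 3 to compound 4 (0.38 log units; beyond the scatter), and its size is a floor only: the limit of > 100000 nM in this assay, at which 1 of the 4 values shown sits. The earlier compounds had shown no such step, yet this one does not set the group of 12 heavy atoms apart from every other group at this position. Measured against the piperidin-1-yl group on the saturated chain carbon bound to a saturated ring carbon, the change gives a 1.9-fold lower number from compound 1 to compound 4 (0.27 log units; within the scatter), so compound 1 and compound 4 cannot be told apart in this test. The comparison of compound 4 with compound 2 cannot be read because compound 2 is known only by a limit: the limit of > 30000 nM in this assay, at which 1 of the 4 values shown sits.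

Going by these compounds, it remains open whether the number in this assay follows the two double bonds outside aromatic rings or simply the size of the entering group. A primary amine or a carboxylic acid on the same saturated chain carbon, or a longer chain carrying the group of compound 4, would show how far changes at this position can move the number.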